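Removing a Methoxy Group from a Rearranged Core

This account rests on a few compounds, and the source may have more. Where it says the series, first, only, none or still open, it means among the compounds named here.

Compound 1, `COc1cc(/C=C/C(=O)/C=C(O)/C=C/c2ccc(O[C@]3(C)C=C[C@@H]([C@@H](C)CC(=O)C=C(C)C)C[C@@H]3O)c(OC)c2)ccc1O`, gives 15700 nM in a functional assay on HepG2 cells (Homo sapiens) for cytotoxicity, read by crystal violet staining, with a stated time of 72 h; on this read-out higher numbers stand for weaker inhibition and lower numbers for stronger inhibition.
Compound 2, `COc1cc(/C=C/C(=O)/C=C(O)/C=C/c2ccc(O[C@]3(C)C=C[C@@H]([C@@H](C)CC(=O)C=C(C)C)C[C@@H]3O)cc2)ccc1O`, gives 17100 nM.
Compound 3, `COc1cc(/C=C/C(=O)/C=C(O)/C=C/c2ccc(O[C@H]3C=C(C)[C@@H](O)C[C@@H]3[C@@H](C)CC(=O)C=C(C)C)c(OC)c2)ccc1O`, gives 15400 nM.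

Compound 1 and compound 2 differ in one place: hydrogen in place of methoxy on an aromatic carbon. That change made a 1.1-fold higher number from compound 1 to compound 2 (0.04 log units; within the scatter), so the two values cannot be told apart. Compound 3 has the same atoms as compound 1, joined differently; the difference between the two cores is not broken down here. The value of compound 3 sits together with those of compound 1 and compound 2, and none of the three can be called more or less potent than the others.

Compound 4, `COc1cc(/C=C/C(O)=C/C(=O)/C=C/c2ccc(O)cc2)ccc1O[C@H]1C=C(C)[C@@H](O)C[C@@H]1[C@@H](C)CC(=O)C=C(C)C`, has not been measured. It differs from compound 3 by hydrogen in place of methoxy on an aromatic carbon. For the measured compounds named here, this is the same kind of change as the one from compound 1 to compound 2, not the same one: in compound 1 the carbon that loses the methoxy is ortho to a large group and meta to a large group, whereas in compound 3 it is ortho to a hydroxy group (1 heavy atom) and meta to a large group.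

For compound 4 the expected step is a 1.1-fold higher number from compound 3 to compound 4 (0.03 log units; within the scatter). This expectation rests on compound 1 and compound 2, whose matching change made a 1.1-fold higher number from compound 1 to compound 2 (0.04 log units; within the scatter). In this assay compound 4 is therefore estimated at 16500 nM, most likely between 9000 nM and 30000 nM.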

Compound 4, half-maximal inhibitory concentration: 13000 nM
Compound 4: middle estimate off by 1.3-fold (0.10 log units), on the high side; the range from low to high includes it.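

In this assay, replacing methoxy with hydrogen on the core of compound 3, which turns a 4-hydroxy-3-methoxyphenyl into a 4-hydroxyphenyl, gives a 1.2-fold lower number from compound 3 to compound 4 (0.07 log units; within the scatter), so these two compounds cannot be told apart. Set beside the matching step on the core of compound 1, this result shows no difference between the two cores: the same change on two cores in this assay, a 1.1-fold higher number (0.04 log units; within the scatter) from compound 1 to compound 2 and a 1.2-fold lower number (0.07 log units; within the scatter) from compound 3 to compound 4, 1.3-fold (0.11 log units) apart, within the scatter of two such steps. In both pairs, then, the swap leaves the number within the scatter, but this does not prove that the methoxy group never matters in this series. Two pairs are few, the methoxy sits in a different place in each, and a small real difference could stay hidden in the scatter.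

The compounds shown leave open whether any other group on that aromatic carbon, such as fluorine, an ethoxy group or an amine, would give a step beyond the scatter. They also leave open whether the same swap would stay this quiet on a compound with a much lower number in this assay, since all the values here lie close together.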